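From compound 2 to compound 4: a shorter tellurium chain

The source may report more compounds than this note shows. Statements on the series, on what has been measured and on what is new or still open speak of the compounds shown alone.

For the measured compounds named here, in a functional assay on HCT-116 cells (Homo sapiens) for cytotoxicity, read by MTT assay, with a stated time of 24 h (on this read-out lower numbers stand for stronger inhibition and higher numbers for weaker inhibition), compound 2 `O=S(=O)(O)OCCCCCCCCCCCC[Te]c1ccccc1` gives 19800 nM, the only number so far. Compound 1 `O=S(=O)(O)OCCCCCCCCCC[Se]c1ccccc1` gives > 100000 nM, which is a limit of the assay. Compound 3 `O=S(=O)(O)OCCCCCCCCCCC[Se]c1ccccc1` gives > 100000 nM, also a limit.

Compound 4 `O=S(=O)(O)OCCCCCCCCC[Te]c1ccccc1` keeps the tellurium of compound 2, and the change is sulfooxy in place of 3-(sulfooxy)propyl on a saturated chain carbon, nine bonds along the chain from a tellurium atom.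

Going by the values given here, two measured steps bear on this. Among the compounds with values here, the first is a step that the two limits leave unreadable from compound 1 to compound 3, so it gives no size for a chain change alone. The second is an at least 5.0-fold higher number from compound 2 to compound 3 (0.70 log units; beyond the scatter), but it exchanges the tellurium group for the selenium group and cannot be read for chain length alone. A modest move towards a higher number in this assay is therefore expected, with low confidence.

The expected change is a 2.3-fold higher number from compound 2 to compound 4 (0.36 log units; beyond the scatter). For compound 4 the estimated value is 45000 nM, with an expected range of 15000 nM to 100000 nM.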

Compound 4, half-maximal inhibitory concentration: 4990 nM
Compound 4: the middle estimate sits 9.0-fold (0.96 log units) above what was measured, and the stated range ends above it.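

For the compounds shown here, with the tellurium atom kept, sulfooxy in place of 3-(sulfooxy)propyl gives in this assay a 4.0-fold lower number from compound 2 to compound 4 (0.60 log units; beyond the scatter), the first step that changes the chain alone and can be read. Among the selenium compounds, the chain step from compound 1 to compound 3 stays unreadable: the limit of > 100000 nM in this assay, at which 2 of the 4 values shown sit. Chain length therefore moves the number in the tellurium pair, although this single pair sets no trend along the chain.

Going by these compounds, it remains open whether the number keeps falling with a tellurium chain shorter than that of compound 4, and whether a selenium compound with that same chain would give a readable value. Also open, on these data alone, is how a carboxylic acid or an amine in place of sulfooxy would behave on the chain of compound 4.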